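Swapping Chloro for Cyclopentylamino: Expected Cell Tolerance

This account rests on a few compounds, and the source may have more. Where it says the series, first, only, none or still open, it means among the compounds named here.

Of the compounds shown here, three have been measured so far in an ADME assay on Vero cells (Chlorocebus sabaeus) for cytotoxicity (a higher number here means that more compound is tolerated, a lower number that less compound is tolerated), and each returned only a limit rather than a number. Compound 1 `Fc1ccc(-c2nn3c(NC4CCCC4)cccc3c2-c2ccnc(NC3CCCC3)n2)cc1` carries a cyclopentylamino group on its fused ring system together with a fluorophenyl group; in this assay compound 1 gave > 160000 nM, a limit of the assay. Compound 2 `COc1ccc(-c2nc3c(NC4CCCC4)cccn3c2-c2ccnc(NC3CCCC3)n2)cc1` carries a methoxyphenyl group instead; in this assay compound 2 gave > 10000 nM, again a limit. Compound 3 `Fc1ccc(-c2nc3c(Cl)cc(Cl)cn3c2-c2ccnc(NC3CCCC3)n2)cc1` has two chloro groups on its fused ring; in this assay compound 3 gave > 40000 nM, also a limit. Where compound 3 stands can thus be stated only as a limit, and the two other values are limits as well, so none of the three can be compared with another beyond saying that all were well tolerated up to where testing stopped.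

Compound 4 `Fc1ccc(-c2nc3c(NC4CCCC4)cc(Cl)cn3c2-c2ccnc(NC3CCCC3)n2)cc1` differs from compound 3 by a single change: cyclopentylamino in place of chloro on an aromatic carbon. Among the compounds with values here, no measured pair shows this exact change. Compound 1 also carries a cyclopentylamino group on its fused ring and sits at the limit of > 160000 nM in this assay, at which 1 of the 3 values shown sits, so no loss of tolerance is expected. The expected step is a step that the limit leaves unreadable from compound 3 to compound 4, within the scatter or toward more tolerance. Compound 4 is expected to give around 80000 nM, with a range from 25000 nM to 300000 nM, and most likely only a limit once more.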

Compound 4, half-maximal cytotoxic concentration: > 40000 nM
Compound 4: only a limit was reported; the forecaster's own chance of this, stated with the estimate: 80%; the middle value lies beyond the limit too.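

Within the data shown here, compound 3 and compound 4 each returned only a limit rather than a number, so no step between them can be read in this assay. The compounds shown leave open at what concentration any of them would start to harm the cells, and whether cyclopentylamino in place of chloro changes that concentration at all.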